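A few compounds are considered here, and "the series" means these few. Any claim that something is new, unique, unknown or untested is made for them only; others in the source may bear on it.

Compound 1 `O=C(NCc1ccc(OC(F)(F)F)c(Cl)c1)c1ccc(S(=O)(=O)Nc2nccs2)cc1` gives 20 nM in an assay on cells for inhibition of sodium channel protein type 3 subunit alpha (Homo sapiens), read by electrophysiology; a lower number here means a stronger inhibitor, a higher number a weaker inhibitor.
Compound 2 `O=C(NCc1ccc(OC(F)(F)F)c(Cl)c1)c1ccc(S(=O)(=O)Nc2ncccn2)c(F)c1` gives 374 nM in this assay.
Compound 3 `O=S(=O)(Nc1nccs1)c1ccc(S(=O)(=O)N2CC[C@H](Oc3ccc(C(F)(F)F)cn3)C2)cc1F` gives 851 nM in this assay.

Among these three, compound 3 stands with the highest number, which means it is the weakest inhibitor of the set. Its nearest neighbour in value is compound 2, and that gap is already beyond the scatter; the gap to compound 1 is far wider. Compound 3 also differs from the other two in more than one place, so none of its steps to them can be traced to a single change.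

Compound 4 `O=S(=O)(Nc1nccs1)c1ccc(S(=O)(=O)N2CC[C@H](Oc3c(Cl)cccc3Cl)C2)cc1F` is the next compound to be measured. It differs from compound 3 in one place: 2,6-dichlorophenyl in place of 5-(trifluoromethyl)pyridin-2-yl on an oxygen on a saturated carbon. Going by the values given here, no pair of measured compounds shows this kind of swap, so nothing among the numbers so far points to a direction. The expectation is therefore a small step, one that may well stay within the scatter, so that compound 4 is estimated to land near compound 3, with the step of a 1.1-fold lower number from compound 3 to compound 4 (0.03 log units; within the scatter) expected. For compound 4 the estimate in this assay is 800 nM, with a range from 250 nM to 2500 nM.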

Compound 4, half-maximal inhibitory concentration in the sodium channel protein type 3 subunit alpha assay: 945 nM
For compound 4 the middle estimate is 1.2-fold (0.07 log units) below the measured one; low and high end bracket the measured number.
By their numbers in the sodium channel protein type 3 subunit alpha assay, from the lowest: compound 1; then compound 2; then compounds 3 and 4 (each within the scatter of the next).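

Going by these compounds alone, in the sodium channel protein type 3 subunit alpha assay, compound 3 gives 851 nM and compound 4 gives 945 nM; this is the first step in the set that changes one place only, and it reads a 1.1-fold higher number from compound 3 to compound 4 (0.05 log units; within the scatter): on an oxygen on a saturated carbon, 2,6-dichlorophenyl stands in for 5-(trifluoromethyl)pyridin-2-yl without moving the number beyond the scatter, even though the ring loses its nitrogen and the trifluoromethyl group gives way to two chlorines. Within the data shown here, in a physicochemical assay for lipophilicity (on this read-out lower numbers stand for lower lipophilicity and higher numbers for higher lipophilicity), compound 4 gives 2.6, whereas the entry for compound 3 reads "not determined" (no result reported), so no step from compound 3 can be read on that scale, and this pair shows nothing about how the swap affects that value. Nothing measured here explains why the two groups give such similar numbers.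

On these data alone, both groups are six-membered aromatic rings, so it remains open whether this position tolerates something quite different, such as a saturated cyclohexyl ring or a chain ending in an amine or a carboxylic acid. Also open, as far as these compounds go, is how any such group would shift the reading in the physicochemical assay, and whether the match seen for this one pair would hold with other groups at this position.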